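The source may hold more compounds than are shown below. What is called first, only, known or untested is meant among the compounds shown, and "the series" means these compounds.

Compound 2, `Cc1cc(-c2ccc(F)cc2)c(/C=C/[C@@H]2C[C@@H](O)CC(=O)O2)c(C(C)C)n1`, gives 9 nM in an assay for inhibition of 3-hydroxy-3-methylglutaryl-coenzyme A reductase (Rattus norvegicus); a higher number here means a weaker inhibitor, a lower number a stronger inhibitor.
Compound 3, `CC(C)c1nc(C2CCCCC2)cc(-c2ccc(F)cc2)c1/C=C/[C@@H]1C[C@@H](O)CC(=O)O1`, gives 4 nM in this assay.
Compound 1, `CCc1nc(-c2ccccc2)cc(-c2ccc(F)cc2)c1/C=C/[C@@H]1C[C@@H](O)CC(=O)O1`, gives 40 nM in this assay.

Compound 2 stands second highest among these three numbers: compound 3 sits at a lower number, and compound 1 at a higher one. Compound 4, `CC(C)c1nc(-c2ccc(F)cc2)cc(-c2ccc(F)cc2)c1/C=C/[C@@H]1C[C@@H](O)CC(=O)O1`, has not yet been measured. It differs from compound 2 in one place: 4-fluorophenyl in place of methyl on an aromatic carbon.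

Within the data shown here, one measured step bears on this change. Going from compound 2 to compound 3 also replaces the methyl at this same spot by a larger ring, and the number dropped, a 2.3-fold lower number from compound 2 to compound 3 (0.35 log units; beyond the scatter). Compound 1 carries a phenyl at that spot but also differs from compound 2 elsewhere, so its higher number cannot be tied to one change alone. A modest lowering of the number is therefore expected in this assay, roughly in line with what compound 3 showed. Compound 4 is expected to give 6 nM, within a range from 2 nM to 20 nM. This expected step, a 1.5-fold lower number from compound 2 to compound 4 (0.18 log units; within the scatter), is estimated to be modest.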

Compound 4, half-maximal inhibitory concentration: 2 nM
For compound 4 the middle estimate is 3.0-fold (0.48 log units) above the measured one, and the stated range covers the measured number.
By their numbers in this assay, from the lowest: compounds 4 and 3 (each within the scatter of the next); then compound 2; then compound 1.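

At this spot on the aromatic carbon next to the ring nitrogen, there is room for far more than a methyl: placing a 4-fluorophenyl there gives a 4.5-fold lower number from compound 2 to compound 4 (0.65 log units; beyond the scatter) in this assay, so a second aromatic ring is tolerated. Exchanging cyclohexyl for 4-fluorophenyl gives a 2.0-fold lower number from compound 3 to compound 4 (0.30 log units; within the scatter), which means that these two large ring groups cannot be told apart here, whether or not the ring is aromatic. No measurement shown here explains why either group gives a lower number than methyl.

From the compounds shown here alone, it remains open whether a ring is needed at all, or whether a longer chain such as butyl or an amine would serve equally well. The role of the fluorine also stays unsettled, since compound 1 has a plain phenyl here but differs from compound 4 in a second place.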